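Fluoro on the phenyl of the dimethoxyphenyl imidazole

This account rests on a few compounds, and the source may have more. Where it says the series, first, only, none or still open, it means among the compounds named here.

Of the compounds shown here, two carry numbers so far. Compound 1 `COc1cc(OC)cc(-n2c(-c3ccccc3)nc(C)c2C)c1` is the dimethoxy member; in a functional assay, read by spectrophotometry, with a stated time of 30 min, tested at 40 uM (on this read-out lower numbers stand for a weaker effect and higher numbers for a stronger effect at the one concentration tested), compound 1 gives 57.6%. Compound 2 `COc1ccc(-n2c(-c3ccccc3)nc(C)c2C)cc1`, the monomethoxy member, gives in this assay a reading of 56.6%. Within the scatter of this read-out the two numbers cannot be told apart, so compound 1 stands level with compound 2 and nothing in the pair points to a trend. Within the data shown here, no step between measured compounds has been counted.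

The next member is compound 3 `COc1cc(OC)cc(-n2c(-c3ccc(F)cc3)nc(C)c2C)c1`. It differs from compound 1 by fluoro in place of hydrogen on an aromatic carbon. Among the measured compounds shown here, with no measured step to lean on, the step from compound 1 to compound 3 is expected to stay inside the scatter, that is a number 0.6 percentage points lower from compound 1 to compound 3 (within the scatter). In this assay compound 3 is therefore estimated at 57%, within a range from 45% to 69%.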

Compound 3, a percentage reported as activity, at one concentration (the size of the read-out at that concentration, not a potency): 57.6%
For compound 3 the middle estimate is 0.6 percentage points below the measured one, within the range that was stated.
By their numbers in this assay, from the lowest: compounds 2, 1 and 3 (each within the scatter of the next).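

In this assay, the change from phenyl to 4-fluorophenyl gives no change at the digits printed from compound 1 to compound 3 (within the scatter), the first step counted in this series. At this place, para to a large group, fluoro in place of hydrogen therefore leaves the size of the read-out at the one tested concentration level, although this single step says nothing about potency. No measured evidence bearing on this result is available.

As far as these compounds go, it remains open whether an amine, a carboxylic acid or a longer chain such as butyl at the same place would also leave the reading level. From the compounds shown here alone, it also remains open whether the same fluoro change would give a comparable step on the monomethoxy member, compound 2.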